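The compounds below may be only part of what the source reports. "The series", "measured", "known", "first", "only" and "open" are said of these compounds alone.

Working notes on the series. Among the measured compounds shown here, compound 1, `Oc1c(C(c2ccc(F)cc2)N2CCCCC2)ccc2ccoc12`, is the only member with a plain number in an assay for inhibition of protein disulfide-isomerase (Homo sapiens), with a stated time of 1 h (a higher number here means a weaker inhibitor, a lower number a stronger inhibitor), where compound 1 gives 560 nM. Compound 2, `Oc1c(C(c2ccncc2)N2CCCCC2)ccc2ccoc12`, shows in this assay a limit rather than a number, < 200 nM, the limit described by the limit of < 200 nM in this assay, at which 1 of the 2 values shown sits. For the measured compounds named here, the single measured step, an at least 2.8-fold lower number from compound 1 to compound 2 (0.44 log units; beyond the scatter), replaces the whole aryl ring bound to the chain carbon.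

Compound 3, `Oc1c(C(c2ccc(C(F)(F)F)cc2)N2CCCCC2)ccc2ccoc12`, differs from compound 1 by trifluoromethyl in place of fluoro on an aromatic carbon. This keeps the phenyl ring of compound 1 and alters only the group on it, so the measured step bears on it only loosely: it shows that the aryl part tolerates change toward a lower number, but gives no direction for a change of this substituent alone. In this assay the step from compound 1 to compound 3 is therefore expected to be a 1.1-fold lower number from compound 1 to compound 3 (0.05 log units; within the scatter), not beyond the scatter. Compound 3 is estimated at 500 nM, with an expected range from 150 nM to 1500 nM.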

Compound 3, half-maximal inhibitory concentration: 300 nM
For compound 3 the middle estimate is 1.7-fold (0.22 log units) above the measured one; low and high end bracket the measured number.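

In this assay, among the compounds shown here, the exchange of fluoro for trifluoromethyl gives a 1.9-fold lower number from compound 1 to compound 3 (0.27 log units; within the scatter), the first measured change of a substituent on the phenyl ring rather than of the whole aryl ring. Compound 1 and compound 3 therefore cannot be separated in this assay, and trifluoromethyl is accepted on this aromatic carbon, para to a large group, without a step beyond the scatter. Nothing shown here gives a cause for this small step.

On these data alone, whether a different group at this place, such as an amine, a carboxylic acid or a nitrile, would produce a step beyond the scatter remains open. Also open, as far as these compounds go, is whether the amine nitrogen in a ring could give way to an open-chain dimethylamino group.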